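This account rests on a few compounds, and the source may have more. Where it says the series, first, only, none or still open, it means among the compounds named here.

Of the compounds shown here, two have been measured in a functional assay on UACC-62 cells (Homo sapiens) for antiproliferative activity, read by sulforhodamine B assay, with a stated time of 48 h; on this read-out lower numbers stand for stronger inhibition of growth and higher numbers for weaker inhibition of growth. Compound 1 `COc1ccc(OC)c(/C=C/c2nnc(Nc3ccc(Cl)cc3)o2)c1` gives 16200 nM, and compound 2 `COc1ccc(OC)c(/C=C/C(=O)N/N=C/c2ccc(Cl)cc2)c1` gives 68 nM. Compound 2 therefore has the lowest of the two numbers, with compound 1 showing a far higher number, a gap well beyond the scatter. Compound 3 `COc1ccc(OC)c(/C=C/C(=O)N/N=C/c2ccccc2)c1` differs from compound 2 in one place: hydrogen in place of chloro on an aromatic carbon. Among the measured compounds shown here, no measured pair shows this change, so the expectation rests on the structures alone. A small loss is expected, estimated as the step of a 2.6-fold higher number from compound 2 to compound 3 (0.42 log units; beyond the scatter). Compound 3 is expected to give about 180 nM, estimated between 60 nM and 550 nM.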

Compound 3, concentration for 50% growth inhibition: 3550 nM
Estimate against measurement, compound 3: 20-fold (1.29 log units) below; measured number above the stated range.
By their numbers in this assay, from the lowest: compound 2; then compound 3; then compound 1.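

In this assay the change from 4-chlorophenyl to phenyl gives a 52-fold higher number from compound 2 to compound 3 (1.72 log units; beyond the scatter) and so shows that a single chloro, on this aromatic carbon para to a large group, accounts for a large part of the growth inhibition seen with compound 2. Compound 1 differs from compound 2 in more than one place, so it could not show this. Nothing measured here explains the size of this step.

Going by these compounds, whether fluoro, methoxy or an amine at this position would match chloro remains open, as does the effect of chloro elsewhere on the ring.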